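Nitro to amino swap on the benzyl sulfone amide

This account rests on a few compounds, and the source may have more. Where it says the series, first, only, none or still open, it means among the compounds named here.

Measured so far in an ADME assay on MRC5 cells (Homo sapiens) for cytotoxicity, read by MTT assay, with a stated time of 72 h; on this read-out higher numbers stand for weaker inhibition of growth and lower numbers for stronger inhibition of growth:
- compound 1, `COc1ccc(CS(=O)(=O)/C=C/c2ccc(OC)c(OC)c2OC)cc1N`: > 30000 nM
- compound 2, `COc1cc(OC)c(/C=C/S(=O)(=O)Cc2ccc(OC)c([N+](=O)[O-])c2)c(OC)c1`: 2910 nM
- compound 3, `COc1ccc(CS(=O)(=O)CC(=O)Nc2c(C)cc(C)cc2C)cc1[N+](=O)[O-]`: 28000 nM

The value of compound 1 is a limit of this assay, not a number; it is the one case in this set where the limit of > 30000 nM in this assay, at which 1 of the 3 values shown sits, applies. Between the two numbers available, compound 3 gives the higher one, with compound 2 as the only other point; the gap between them is well beyond the scatter.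

The step to be made goes from compound 3 to compound 4, `COc1ccc(CS(=O)(=O)CC(=O)Nc2c(C)cc(C)cc2C)cc1N`. The change is amino in place of nitro on an aromatic carbon.

Among the measured compounds shown here, no measured pair in the set differs in this one place alone. What can be said is that compound 1, which carries the amino group, gives only a limit, whereas compound 2, with the nitro group, gives a number; compound 3 already sits close to that limit. For compound 4 the number is expected to move upward, a step of a 1.8-fold higher number from compound 3 to compound 4 (0.25 log units; within the scatter) that may stay within the scatter, with a real chance that this assay reports only a limit. Compound 4 is estimated at 50000 nM, with a range from 20000 nM to 150000 nM.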

Compound 4, concentration for 50% growth inhibition: > 30000 nM
Compound 4 gave a limit, no number; the forecaster's own chance of this, stated with the estimate: 65%; the middle value lies beyond the limit too.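

In this assay, amino in place of nitro on an aromatic carbon, ortho to a methoxy group, can now be read as a single change, with an at least 1.0-fold higher number from compound 3 to compound 4 (0.02 log units; that floor lies within the scatter). Compound 4 gives > 30000 nM, which is a limit and not a number, so the step fixes only a floor and shows no change beyond the scatter. The two compounds at this limit, compound 1 and compound 4, both carry the amino group: the limit of > 30000 nM in this assay, at which 2 of the 4 values shown sit.

From the compounds shown here alone, how far compound 4 lies past the limit remains unknown, and so does the true size of the step, which may be negligible or large. Also open, going by these compounds, is whether a hydroxyl or a dimethylamino group on this same aromatic carbon would give a number in this assay or stay at the limit.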